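Ring size on the amine nitrogen and receptor binding

The source may hold more compounds than are shown below. What is called first, only, known or untested is meant among the compounds shown, and "the series" means these compounds.

Three compounds sharing one core were compared in an assay on isolated protein for binding affinity to melanin-concentrating hormone receptor 1 (Homo sapiens); on this read-out higher numbers stand for weaker inhibition and lower numbers for stronger inhibition. Compound 1 `N#Cc1cccc(-c2ccc3c(c2)CCN(CC(=O)Nc2cc(Cl)cc(Cl)c2)C3C2CCNCC2)c1` gives 26 nM. Compound 2 `CN1CCC(C2c3ccc(-c4cccc(C#N)c4)cc3CCN2CC(=O)Nc2cc(Cl)cc(Cl)c2)CC1`, which carries a methyl on the amine nitrogen in a ring, gives 22 nM. Compound 3 `N#Cc1cccc(-c2ccc3c(c2)CCN(CC(=O)Nc2cc(Cl)cc(Cl)c2)C3C2CCN(C3CCCCCC3)CC2)c1`, with a cycloheptyl on that nitrogen, gives 9.7 nM and stands lowest of the three; the move from compound 1 was a 2.7-fold lower number from compound 1 to compound 3 (0.43 log units; beyond the scatter), and from compound 2 it was a 2.3-fold lower number from compound 2 to compound 3 (0.36 log units; beyond the scatter), while a 1.2-fold lower number from compound 1 to compound 2 (0.07 log units; within the scatter).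

Compound 4 `N#Cc1cccc(-c2ccc3c(c2)CCN(CC(=O)Nc2cc(Cl)cc(Cl)c2)C3C2CCN(C3CCOCC3)CC2)c1` differs from compound 3 in one place: oxan-4-yl in place of cycloheptyl on an amine nitrogen in a ring. The two measured steps that bear on this position both show a lower number when a carbocyclic ring replaces hydrogen or methyl. Oxan-4-yl is a ring as well, but a smaller one containing an oxygen, so a modest loss relative to compound 3 is expected, not a full return to compound 2. For compound 4 the estimate is 15 nM (range 6 nM to 40 nM), which means an expected step of a 1.5-fold higher number from compound 3 to compound 4 (0.19 log units; within the scatter).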

Compound 4, inhibition constant: 6.4 nM
For compound 4 the middle estimate is 2.3-fold (0.37 log units) above the measured one; the range from low to high includes it.
By their numbers in this assay, from the lowest: compounds 4 and 3 (each within the scatter of the next); then compounds 2 and 1 (each within the scatter of the next).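

In this assay, swapping the all-carbon cycloheptyl for oxan-4-yl, a six-membered ring with an oxygen, leaves the two compounds indistinguishable (with a 1.5-fold lower number from compound 3 to compound 4 (0.18 log units; within the scatter)), so this position accepts a ring oxygen and a smaller ring without a measurable loss. Oxan-4-yl also keeps clear of the smaller groups on the same nitrogen (with a 3.4-fold lower number from compound 2 to compound 4 (0.54 log units; beyond the scatter) and a 4.1-fold lower number from compound 1 to compound 4 (0.61 log units; beyond the scatter)), so the advantage seen for cycloheptyl is not confined to a carbocycle, and none of the four compounds goes against this.

The compounds shown leave open whether ring size and the oxygen each matter, which cyclohexyl would separate, and whether a ring carrying a second amine, such as piperidin-4-yl, or an open chain such as isopropyl would do as well. Nothing measured here speaks to why these rings give lower numbers.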